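Replacing Dimethylamino with Trifluoromethoxy in Compound 1

The source may report more compounds than this note shows. Statements on the series, on what has been measured and on what is new or still open speak of the compounds shown alone.

In a functional assay on HeLa cells (Homo sapiens) for cytotoxicity, read by MTT assay, with a stated time of 2 days (a higher number here means a weaker inhibitor, a lower number a stronger inhibitor), compound 1 (`Cc1ccc2nc(-c3ccccc3N(C)C)[nH]c(=O)c2c1`) gives 14000 nM and compound 3 (`COc1cccc(-c2nc3cc(C)ccc3c(=O)[nH]2)c1`) gives 8940 nM, two numbers that lie within the scatter of each other. Compound 2 (`Cc1cccc(-c2nc3ccc(C)cc3c(=O)[nH]2)c1`) is reported only as a limit, > 50000 nM. The next step leads to compound 4 (`Cc1ccc2nc(-c3ccccc3OC(F)(F)F)[nH]c(=O)c2c1`), with trifluoromethoxy in place of dimethylamino on an aromatic carbon, ortho to a large group (trifluoromethoxy in place of dimethylamino on an aromatic carbon). Going by the values given here, no measured pair isolates this change, so in this assay only a small move toward a higher number is expected, possibly none beyond the scatter, as the estimated 1.3-fold higher number from compound 1 to compound 4 (0.11 log units; within the scatter) shows. Compound 4 is estimated at 18000 nM, with an expected range of 6000 nM to 50000 nM.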

Compound 4, half-maximal inhibitory concentration: 850 nM
The estimate for compound 4 lay 21-fold (1.33 log units) above the measured number; measured number below the stated range.
By their numbers in this assay, from the lowest: compound 4; then compounds 3 and 1 (each within the scatter of the next). At a limit, above all of these: compound 2.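

This is the first pair among the compounds shown that differs in one place, and so the first direct reading of this position in this assay. On an aromatic carbon ortho to a large group, trifluoromethoxy in place of dimethylamino gives a 16-fold lower number from compound 1 to compound 4 (1.22 log units; beyond the scatter), so this position responds strongly to this change. Nothing shown here accounts for the size of this step.

As far as these compounds go, whether the step reflects the arrival of trifluoromethoxy or the loss of dimethylamino remains open. Methoxy, trifluoromethyl or a plain hydrogen at this position could separate the two.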